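The compounds below may be only part of what the source reports. "The series", "measured", "known", "first", "only" and "open" are said of these compounds alone.

Compound 1 `Fc1ccccc1[C@H](Nc1nnc(-c2c[nH]c3ncccc23)o1)C1CC1`: 5 ug/mL
Compound 2 `Fc1ncccc1[C@H](Nc1nnc(-c2c[nH]c3ncccc23)o1)C1CC1`: 200 ug/mL

In an ADME assay for solubility, in simulated intestinal fluid (on this read-out lower numbers stand for lower solubility and higher numbers for higher solubility), compound 2 gives 200 ug/mL, the higher of the two numbers, and compound 1 gives 5 ug/mL. Compound 3 `Fc1cnc2[nH]cc(-c3nnc(N[C@@H](c4cccnc4F)C4CC4)o3)c2c1` differs from compound 2 by one change, fluoro in place of hydrogen on an aromatic carbon. Among the compounds with values here, the only measured step, a 40-fold higher number from compound 1 to compound 2 (1.60 log units; beyond the scatter), is large and beyond the scatter. It swaps 2-fluorophenyl for 2-fluoropyridin-3-yl, though, and so lies elsewhere in the structure. Within the data shown here, it bears on the new change only indirectly, and no measured pair shows that change itself. A modest fall in this assay is therefore expected, with little confidence in its direction, and it may not clear the scatter. The expected change is a 1.8-fold lower number from compound 2 to compound 3 (0.26 log units; within the scatter). For compound 3 the estimated value is 110 ug/mL, with an expected range of 35 ug/mL to 280 ug/mL.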

Compound 3, solubility: 160 ug/mL
For compound 3 the middle estimate is 1.5-fold (0.16 log units) below the measured one, and the stated range covers the measured number.
By their numbers in this assay, from the lowest: compound 1; then compounds 3 and 2 (each within the scatter of the next).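

In this assay fluoro in place of hydrogen on an aromatic carbon, two atoms from the ring nitrogen, gives a 1.3-fold lower number from compound 2 to compound 3 (0.10 log units; within the scatter) and so leaves the read-out of compound 3 indistinguishable from that of compound 2. Within the data shown here, this is the first step measured at this place on the six-membered aromatic ring with 1 nitrogen, as the earlier step lay elsewhere in the structure, in the swap of 2-fluorophenyl for 2-fluoropyridin-3-yl. No measurement at hand explains the result.

Going by these compounds, whether a different group at this same place, such as chloro, methoxy or an amine, would also leave the read-out unmoved stays open. So does whether the same fluoro on the core of compound 1, with its 2-fluorophenyl, would give a step of similar size.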